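The source may hold more compounds than are shown below. What is called first, only, known or untested is meant among the compounds shown, and "the series" means these compounds.

Working notes on the series.

Compound 1 `COC(=O)C[C@H](NC(=O)OC(C)(C)C)C(=O)N(Cc1ccc(F)cc1)C1(C(=O)NCc2ccccc2)CCN(Cc2ccccc2)CC1` is the reference point. In an ADME assay on MDCK cells (Canis lupus familiaris) for cytotoxicity, read by microscopy, with a stated time of 72 h (a higher number here means that more compound is tolerated, a lower number that less compound is tolerated), compound 1 gives only a limit, > 100000 nM, and no number; see (the limit of > 100000 nM in this assay, at which 1 of the 3 values shown sits). Compound 2 `COC(=O)C[C@H](NC(=O)OC(C)(C)C)C(=O)N(Cc1ccc(F)cc1)C1(C(=O)NCc2ccccc2)CCN(C2CCCCC2)CC1` gives 73000 nM in this assay, and compound 3 `COC(=O)C[C@H](NC(=O)OC(C)(C)C)C(=O)N(Cc1ccc(F)cc1)C1(C(=O)NCS(=O)(=O)c2ccc(C)cc2)CCN(Cc2ccccc2)CC1` gives 4000 nM.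

Two steps from compound 1 have been measured. The change to a cyclohexyl in place of benzyl on an amine nitrogen in a ring gives an at least 1.3-fold lower number from compound 1 to compound 2 (0.13 log units; that floor lies within the scatter). The change to (4-methylphenyl)sulfonyl in place of phenyl on a saturated chain carbon bound to an amide-type nitrogen gives an at least 25-fold lower number from compound 1 to compound 3 (1.39 log units; beyond the scatter).

Compound 4 `COC(=O)C[C@H](NC(=O)OC(C)(C)C)C(=O)N(Cc1ccc(C(F)(F)F)cc1)C1(C(=O)NCc2ccccc2)CCN(Cc2ccccc2)CC1` differs from compound 1 by trifluoromethyl in place of fluoro on an aromatic carbon. Within the data shown here, neither measured step touches this benzyl group, so neither bears directly on it; the only guidance is that the change to compound 2, an alteration of comparable scale, stayed within the scatter, while only the sulfonyl change moved the number. The expectation for compound 4 is therefore a step of an at least 1.2-fold lower number from compound 1 to compound 4 (0.09 log units; that floor lies within the scatter), not clearly beyond the scatter, and an estimated value of 80000 nM, within 30000 nM to 100000 nM.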

Compound 4, minimum cytotoxic concentration: 84000 nM
Compound 4: middle estimate off by 1.1-fold (0.02 log units), on the low side, within the range that was stated.
By their numbers in this assay, from the lowest: compound 3; then compounds 2 and 4 (each within the scatter of the next). At a limit, above all of these: compound 1.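

Among these compounds, on the 4-fluorobenzyl group, which no earlier compound varied, the change to 4-(trifluoromethyl)benzyl gives an at least 1.1-fold lower number from compound 1 to compound 4 (0.07 log units; that floor lies within the scatter) in this assay. On these data alone, this figure is only a floor, and the true size of the step stays unknown, as compound 1 gives a limit and no number: the limit of > 100000 nM in this assay, at which 1 of the 4 values shown sits. Even so, replacing a group of 1 heavy atom with one of 4 heavy atoms on this aromatic carbon gives no step that can be claimed beyond the scatter, whereas the sulfonyl change gives an at least 25-fold lower number from compound 1 to compound 3 (1.39 log units; beyond the scatter).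

The compounds shown leave open how an amine, a carboxylic acid or a nitrile on this same aromatic carbon would read. They also leave open whether trifluoromethyl gives a similar reading in the sulfonyl series of compound 3, where a number is available as the starting point.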